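Swapping ring oxygen for sulfur in a biphenyl ether agonist

The source may hold more compounds than are shown below. What is called first, only, known or untested is meant among the compounds shown, and "the series" means these compounds.

Compound 1 `CC(Oc1ccccc1-c1ccccc1)C1=NCCO1` was tested in a functional assay on CHO cells for agonist activity at Alpha-2C adrenergic receptor (Homo sapiens); on this read-out higher numbers stand for larger maximal responses and lower numbers for smaller maximal responses. In this assay compound 1 gives < 0.3, which is a limit of the assay rather than a number. Compound 2 `CC(Oc1ccccc1-c1ccccc1O)C1=NCCN1` was also tested, and in this assay compound 2 gives < 0.3, again a limit of the assay and not a number. So compound 1 stands at the lowest point the numbers shown can mark, and no step between measured compounds is available to learn from.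

Compound 3 `CC(Oc1ccccc1-c1ccccc1)C1=NCCS1` has not yet been measured. It differs from compound 1 by a group of 5 heavy atoms (3 carbon, 1 nitrogen, 1 sulfur; one five-membered non-aromatic ring with 2 hetero atoms) in place of a group of 5 heavy atoms (3 carbon, 1 nitrogen, 1 oxygen; one five-membered non-aromatic ring with 2 hetero atoms), on a saturated chain carbon bound to an oxygen on an aromatic ring and a saturated chain carbon. With both measured values sitting at the limit of < 0.3 in this assay, at which 2 of the 2 values shown sit, the step from compound 1 to compound 3 is expected to be small and of no settled direction, within the usual scatter: a step that the limit leaves unreadable from compound 1 to compound 3. Compound 3 is therefore estimated at 0.2, with a range from 0.05 to 0.45.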

Compound 3, intrinsic activity: the largest response reached, as a fraction of the reference agonist's: < 0.3
Compound 3: only a limit was reported (the forecaster's own chance of this, stated with the estimate: 65%); the middle value lies beyond the limit too.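

The step from compound 1 to compound 3 cannot be read, as each gives only a limit of the assay and not a number: the limit of < 0.3 in this assay, at which 3 of the 3 values shown sit.

The compounds shown leave open whether any of them reaches a maximal response that can be given as a number, and whether the sulfur-containing group differs from the oxygen-containing group at all.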